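Moving the Methyl Step from One Core to the Other

The compounds below may be only part of what the source reports. "The series", "measured", "known", "first", "only" and "open" are said of these compounds alone.

Compound 1 `Nc1cccc(/C=C/c2ccc(O)cc2)c1` and compound 2 `Nc1ccc(/C=C/c2ccc(O)cc2)cc1` are built from the same atoms joined differently; the difference between the two cores is not broken down here. Going by the values given here, in an ADME assay on HEK293 cells (Homo sapiens) for inhibition, read by MTT assay, with a stated time of 2 days (a lower number here means a stronger inhibitor, a higher number a weaker inhibitor), compound 1 gives 7 ug/mL, while compound 2 gives 0.8 ug/mL, the lowest of the three numbers so far, with its steps to both other compounds lying beyond the scatter. Compound 3 `COc1ccc(/C=C/c2cccc(N)c2)cc1` carries the change methyl in place of hydrogen on an oxygen on an aromatic ring on the core of compound 1, and in this assay compound 3 gives 11 ug/mL; the step of a 1.6-fold higher number from compound 1 to compound 3 (0.20 log units; within the scatter) is within the scatter. The same change, (methyl in place of hydrogen on an oxygen on an aromatic ring), occurs a second time, now on the core of compound 2, and gives compound 4 `COc1ccc(/C=C/c2ccc(N)cc2)cc1`, which has not yet been measured in this assay. Among the compounds with values here, the step of a 1.6-fold higher number from compound 2 to compound 4 (0.21 log units; within the scatter) is expected to be about as large as the earlier step of a 1.6-fold higher number from compound 1 to compound 3 (0.20 log units; within the scatter), which is the only precedent for this change. Compound 4 is therefore estimated at 1.3 ug/mL in this assay, with a range from 0.5 ug/mL to 3.5 ug/mL.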

Compound 4, half-maximal inhibitory concentration: 0.012 ug/mL
Compound 4: the middle estimate sits 110-fold (2.03 log units) above what was measured; measured number below the stated range.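

In this assay, the change from hydroxy to methoxy on the core of compound 2 gives a 67-fold lower number from compound 2 to compound 4 (1.82 log units; beyond the scatter), a large step for the addition of a single methyl. Set beside the only other case of this change, the step does not carry over from one core to the other at the same size: the same change on two cores in this assay, a 1.6-fold higher number (0.20 log units; within the scatter) from compound 1 to compound 3 and a 67-fold lower number (1.82 log units; beyond the scatter) from compound 2 to compound 4, 100-fold (2.02 log units) apart, beyond the scatter of two such steps This shows that, for these two cores, the size of the step depends on the core that carries it, so the step on the core of compound 1 was no reliable guide to the step on the core of compound 2; it does not show what in the two cores causes the gap, and two pairs give no rule for any other core in the series.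

The compounds shown leave open whether the large step is particular to methyl or would also appear with an ethyl group, a longer chain or an acetyl group on that oxygen. Also open, as far as these compounds go, is whether the gap between the two cores remains when the amine shared by all four compounds gives way to an amide or a dimethylamino group.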